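Sulfur-to-selenium change on compound 2

The source may report more compounds than this note shows. Statements on the series, on what has been measured and on what is new or still open speak of the compounds shown alone.

compound 1 `N#CSc1nccc(Cl)n1`: 35000 nM
compound 2 `Cc1noc(C)c1CSC#N`: 4800 nM

Both were run in a functional assay on MCF7 cells (Homo sapiens) for cytotoxicity, read by MTT assay, with a stated time of 72 h; on this read-out higher numbers stand for weaker inhibition of growth and lower numbers for stronger inhibition of growth. Compound 2 holds the lower of the two numbers; compound 1 lies beyond the scatter from it, so the pair is distinguishable. Compound 3 `Cc1noc(C)c1C[Se]C#N` is not yet measured. It differs from compound 2 in one place: a group of 3 heavy atoms (1 carbon, 1 nitrogen, 1 selenium; no ring) in place of a group of 3 heavy atoms (1 carbon, 1 nitrogen, 1 sulfur; no ring), on a saturated chain carbon bound to an aromatic carbon. Within the data shown here, no step between measured compounds informs this change, so its size is not anchored by data; a small move toward a lower number, not assured beyond the scatter, is expected. For compound 3 the expected value is 2500 nM, with a range of 700 nM to 9000 nM. The expected step is a 1.9-fold lower number from compound 2 to compound 3 (0.28 log units; within the scatter).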

Compound 3, concentration for 50% growth inhibition: 2200 nM
Compound 3: the middle estimate sits 1.1-fold (0.06 log units) above what was measured; the range from low to high includes it.
By their numbers in this assay, from the lowest: compound 3; then compound 2; then compound 1.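

Read in this assay the change gives a 2.2-fold lower number from compound 2 to compound 3 (0.34 log units; beyond the scatter) and so provides the first measured single-place step in the series, showing that on a saturated chain carbon bound to an aromatic carbon, selenium in place of sulfur is tolerated and shifts the read-out modestly. Nothing available accounts for this step.

On these data alone, whether the same exchange would move the number on the core of compound 1 remains open. Also open, as far as these compounds go, is how a carboxylic acid or an amine would compare with either group at this place.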